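A few compounds are considered here, and "the series" means these few. Any claim that something is new, unique, unknown or untested is made for them only; others in the source may bear on it.

Compound 1 `CC(C)(C)c1ccc(/C=C(/C(=O)Nc2ccc3c(c2)OCCO3)c2ccccc2)cc1` and compound 2 `Cc1nc(C(F)(F)F)ccc1/C=C/C(=O)Nc1ccc2c(c1)OCCO2` share the same amide-linked bicyclic portion and were both run in a functional assay on CHO cells for inhibition of transient receptor potential cation channel subfamily V member 1 (Homo sapiens); a higher number here means a weaker inhibitor, a lower number a stronger inhibitor. For compound 1 the result is a limit of the assay rather than a number, > 4000 nM, and (the limit of > 4000 nM in this assay, at which 1 of the 2 values shown sits). In this assay, for the measured compounds named here, compound 2 gives 870 nM, which is the only actual number among the two results. Compound 3 `O=C(/C=C/c1ccc(C(F)(F)F)nc1N1CCCCC1)Nc1ccc2c(c1)OCCO2` has not been measured yet. It differs from compound 2 in one place: piperidin-1-yl in place of methyl on an aromatic carbon next to the ring nitrogen, ortho to a large group and meta to the trifluoromethyl group. Going by the values given here, no pair of measured compounds shows what such a change does here, so no measured step can be leaned on. The expectation for compound 3 is a modest shift toward stronger inhibition, a 2.2-fold lower number from compound 2 to compound 3 (0.34 log units; beyond the scatter), though a result within the scatter of compound 2 is also plausible. Compound 3 is therefore estimated at 400 nM in this assay, with a likely range from 100 nM to 2000 nM.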

Compound 3, half-maximal inhibitory concentration: 54 nM
For compound 3 the middle estimate is 7.4-fold (0.87 log units) above the measured one; the measured number lies below the stated range.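

In this assay, putting piperidin-1-yl in place of methyl on this aromatic carbon next to the ring nitrogen gives a 16-fold lower number from compound 2 to compound 3 (1.21 log units; beyond the scatter), with the rest of the molecule unchanged. For the compounds shown here, this is the first measured step at this position, and it shows that the position accepts a much larger group than methyl, one carrying a six-membered non-aromatic ring, and that the exchange brings a large gain in inhibition rather than a loss. Nothing measured for these compounds accounts for the size of this gain.

With a single step at this position, the compounds shown leave open which part of piperidin-1-yl carries the gain: the ring nitrogen attached to the aromatic carbon, the ring itself or simply the larger number of atoms. On these data alone, a dimethylamino group, a morpholin-4-yl ring or a cyclohexyl ring on the same carbon would separate these readings, and it also remains open whether the gain would hold with the other parts of the molecule changed.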